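This account rests on a few compounds, and the source may have more. Where it says the series, first, only, none or still open, it means among the compounds named here.

Within the data shown here, compound 1 `Cc1cccc(C(=O)Nc2nn[nH]n2)n1` holds the highest of the three numbers measured so far: in a functional assay on the whole organism for inhibition, with Rattus norvegicus as the target, at a dose of 3 mg/kg by the oral route (on this read-out higher numbers stand for a stronger effect at the one dose given and lower numbers for a weaker effect), compound 1 gives 46%. Compound 2 `COc1cccc(C(=O)Nc2nn[nH]n2)n1` gives 36% in this assay, and compound 3 `CCCCOc1cccc(C(=O)Nc2nn[nH]n2)n1` gives 18%. Every measured step alters the methyl of compound 1 or what replaces it: a number 10 percentage points lower from compound 1 to compound 2 (within the scatter), a number 28 percentage points lower from compound 1 to compound 3 (beyond the scatter), and a number 18 percentage points lower from compound 2 to compound 3 (beyond the scatter). Compound 4 `Cc1cc(C)nc(C(=O)Nc2nn[nH]n2)c1` keeps that methyl and differs from compound 1 only by methyl in place of hydrogen on an aromatic carbon. Among the measured compounds shown here, no measured step adds a group elsewhere on the shared core, so those steps bear on this one only loosely, and in this assay a step within the scatter, or a small decrease, is expected. Compound 4 is therefore estimated to give 40% in this assay, between 20% and 60%. The expected step is a number 6 percentage points lower from compound 1 to compound 4 (within the scatter).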

Compound 4, a percentage reported as inhibition, in the whole organism at one dose (the size of the read-out at that dose, not a potency): 44%
Beside the measured number, compound 4's estimate is 4 percentage points below it; low and high end bracket the measured number.
By their numbers in this assay, from the lowest: compound 3; then compounds 2, 4 and 1 (each within the scatter of the next).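

In this assay, methyl in place of hydrogen on the aromatic carbon opposite the ring nitrogen gives a number 2 percentage points lower from compound 1 to compound 4 (within the scatter). Among these compounds, this is the first reading at this position, as the earlier steps only altered the existing methyl, and it shows that the shared core can carry this added methyl with no change beyond the scatter. Nothing available explains this result. As far as these compounds go, what remains open is whether a larger group here, such as a butoxy chain, an amine or a carboxylic acid, would also stay within the scatter. A single methyl says nothing about those groups.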